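The compounds below may be only part of what the source reports. "The series", "measured", "known", "first", "only" and "open" are said of these compounds alone.

In an ADME assay on microsomes from liver (Homo sapiens) for metabolic stability (on this read-out higher numbers stand for fast clearance and lower numbers for slow clearance), compound 1 (`Cc1ccc2[nH]c(C(=O)N[C@H]3CN(S(=O)(=O)c4ccccc4)C[C@@H]3C(=O)N[C@@H]3CCCN(C)C3)cc2c1`) gives 50 mL.min-1.g-1 and compound 2 (`O=C(N[C@H]1CN(S(=O)(=O)c2ccccc2)C[C@@H]1C(=O)N1C[C@H]2CCNC[C@H]21)c1cc(-c2ccccc2Cl)on1`) gives 7.3 mL.min-1.g-1. Compound 2 thus holds the lower of the two numbers, with a gap to compound 1 that lies beyond the scatter. Compound 3 (`O=CN1CCC[C@H](NC(=O)[C@H]2CN(S(=O)(=O)c3ccccc3)C[C@@H]2NC(=O)c2cc(-c3ccccc3Cl)on2)C1`) departs from compound 2 in one place, on a carbonyl carbon: a group of 9 heavy atoms (6 carbon, 2 nitrogen, 1 oxygen; one six-membered non-aromatic ring with 1 hetero atom) in place of a group of 8 heavy atoms (6 carbon, 2 nitrogen; one four-membered non-aromatic ring with 1 hetero atom, one six-membered non-aromatic ring with 1 hetero atom), on a carbonyl carbon. The one four-membered non-aromatic ring leaves with that group. Among the measured compounds shown here, no two measured compounds differ in one place only, so no measured step speaks directly to this change. The expectation therefore starts from compound 2 at 7.3 mL.min-1.g-1 and allows for a small upward step in this assay, well short of the gap to compound 1. The expected change is a 2.2-fold higher number from compound 2 to compound 3 (0.34 log units; beyond the scatter). For compound 3 the estimated value is 16 mL.min-1.g-1, with an expected range from 6 mL.min-1.g-1 to 40 mL.min-1.g-1.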

Compound 3, intrinsic clearance in microsomes in the Homo sapiens assay: > 259 mL.min-1.g-1
Compound 3: no number, only a limit; the forecaster's own chance of this, stated with the estimate: 2%; at least 16-fold (1.20 log units) between middle value and limit.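

The first single-place step read at this position, on a carbonyl carbon, is large: in the Homo sapiens assay the group with one six-membered non-aromatic ring in place of the group with one four-membered and one six-membered non-aromatic ring gives an at least 35-fold higher number from compound 2 to compound 3 (1.54 log units; beyond the scatter), so this position can move clearance far more than compound 2 alone could show. As far as these compounds go, compound 3 gives > 259 mL.min-1.g-1, which is a limit of the assay and not a number, so the full size of the step stays unknown. In a physicochemical assay for lipophilicity, measured as octanol-water partition, at pH 7.4 (on this read-out higher numbers stand for higher lipophilicity and lower numbers for lower lipophilicity), compound 2 gives 1.7 and compound 3 gives 3.1. In the physicochemical assay the same change gives a number 1.40 log units higher from compound 2 to compound 3 (beyond the scatter), so the rise in clearance comes with a rise in lipophilicity: the measured distribution coefficient of compound 2, 1.7, and of compound 3, 3.1, a number 1.40 log units higher (beyond the scatter).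

This single pair cannot separate the effect of lipophilicity from that of the group itself. From the compounds shown here alone, how a group carrying a carboxylic acid would behave at this place also remains open.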